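This account rests on a few compounds, and the source may have more. Where it says the series, first, only, none or still open, it means among the compounds named here.

Measured so far in a functional assay on the whole organism (strain Jcl:SD) for inhibition, with Rattus norvegicus as the target, with stated times of 3 min and 3 h, at a dose of 1 mg/kg by the intravenous route; on this read-out lower numbers stand for less inhibition and higher numbers for more inhibition at the one dose given (going by the name of the read-out):

compound 1 `CNCc1cc(-c2ccccc2)n(S(=O)(=O)c2ccc(C)cc2)c1` — compound 1 gives 66%
compound 2 `CNCc1cc(-c2ccccc2C(F)(F)F)n(S(=O)(=O)c2ccc(C)cc2)c1` — compound 2 gives 86%
compound 3 `CNCc1cc(-c2ccccc2F)n(S(=O)(=O)c2ccc(C)cc2)c1` — compound 3 gives 91%

Compound 3 holds the highest number of the three, yet its gap to compound 2 is within the scatter, so no order between those two can be claimed; only compound 1 sits clearly lower. The measured steps of a number 25 percentage points higher from compound 1 to compound 3 (beyond the scatter) and a number 20 percentage points higher from compound 1 to compound 2 (beyond the scatter) are both modest, and a number 5 percentage points higher from compound 2 to compound 3 (within the scatter) is within the scatter.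

Compound 4 `CNCc1cc(-c2ccc(F)cc2)n(S(=O)(=O)c2ccc(C)cc2)c1` differs from compound 3 as follows: 4-fluorophenyl in place of 2-fluorophenyl on an aromatic carbon. For the measured compounds named here, no measured pair compares two placements of the same group on that ring, so none of the measured steps bears directly on this change; only the shared presence of a fluorine on the ring, as in compound 3, offers any footing. The direction in this assay is therefore open, and a drift somewhat below compound 3 is as plausible as none. The estimated step is a number 15 percentage points lower from compound 3 to compound 4 (beyond the scatter), and compound 4 is expected to give about 76%, in the range 55% to 95%.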

Compound 4, a percentage reported as inhibition, in the whole organism at one dose (the size of the read-out at that dose, not a potency) in the Rattus norvegicus assay: 86%
Compound 4: the middle estimate sits 10 percentage points below what was measured; measured number inside the range.
By their numbers in the Rattus norvegicus assay, from the lowest: compound 1; then compounds 2, 4 and 3 (each within the scatter of the next).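

In the Rattus norvegicus assay, 4-fluorophenyl in place of 2-fluorophenyl gives a number 5 percentage points lower from compound 3 to compound 4 (within the scatter), so the fluorine placement on this ring cannot be separated here, while a number 20 percentage points higher from compound 1 to compound 4 (beyond the scatter) adds a second fluorine placement that stands clear of the unsubstituted phenyl. In a physicochemical assay for acid dissociation, compound 3 gives 9.48 and compound 4 gives 9.4, a step of a number 0.08 log units lower from compound 3 to compound 4 (within the scatter) that also separates neither placement. No supporting data bear on why these results arise.

Open, as far as these compounds go, is whether a methoxy group or an amine on that phenyl ring would keep this level of inhibition. Also open, from the compounds shown here alone, is how a longer chain in place of the (methylamino)methyl group would read.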